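The source may report more compounds than this note shows. Statements on the series, on what has been measured and on what is new or still open speak of the compounds shown alone.

Measured compounds:
compound 1 `O=C(O)[C@@H]1CCCN1C(=O)/C=C/c1ccncc1-c1ccc2ccccc2c1`, giving 67% in an assay on a protein complex for inhibition of CDK8/Cyclin C (Homo sapiens), with a stated time of 1 h, tested at 10 uM; on this read-out higher numbers stand for more inhibition at the one concentration tested (going by the name of the read-out) and lower numbers for less inhibition
compound 2 `NNC(=O)CCc1ccncc1-c1ccc2ccccc2c1`, giving 102% in this assay
compound 3 `COC(=O)/C=C/c1ccncc1-c1ccc2ccccc2c1`, giving 102% in this assay

Compound 3 stands level with compound 2 at the digits printed, and the two of them share the highest reading of the three; compound 1 lies furthest away, with a reading a number 35 percentage points higher from compound 1 to compound 3 (beyond the scatter). Within the data shown here, the one step that changes the same carbonyl carbon, methoxy in place of 2-carboxypyrrolidin-1-yl, was that large one from compound 1 to compound 3. The other step, 2-(methoxycarbonyl)ethenyl in place of 2-(aminocarbamoyl)ethyl, gave no change at the digits printed from compound 2 to compound 3 (within the scatter).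

Compound 4 `NC(=O)/C=C/c1ccncc1-c1ccc2ccccc2c1` differs from compound 3 by amino in place of methoxy on a carbonyl carbon. Since compound 2 and compound 3 read alike while carrying different groups on that carbonyl carbon, and only the 2-carboxypyrrolidin-1-yl of compound 1 lowered the reading, a small step at most is expected here, a number 7 percentage points lower from compound 3 to compound 4 (within the scatter). Compound 4 is therefore estimated at 95%, between 78% and 105%.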

Compound 4, a percentage reported as inhibition, at one concentration (the size of the read-out at that concentration, not a potency): 102%
Compound 4: middle estimate off by 7 percentage points, on the low side, and the stated range covers the measured number.
By their numbers in this assay, from the lowest: compound 1; then compounds 2, 3 and 4 (each within the scatter of the next).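

In this assay, amino in place of methoxy on the carbonyl carbon gave no change at the digits printed from compound 3 to compound 4 (within the scatter), so at this position a group with a hydrogen-bond donor and no acceptor reads the same as one with an acceptor and no donor. The other two steps place compound 4 with the high readings: 2-carbamoylethenyl in place of 2-(aminocarbamoyl)ethyl gave no change at the digits printed from compound 2 to compound 4 (within the scatter), while amino in place of 2-carboxypyrrolidin-1-yl gave a number 35 percentage points higher from compound 1 to compound 4 (beyond the scatter), leaving 2-carboxypyrrolidin-1-yl as the only group shown on this carbonyl carbon with a lower reading. Nothing measured here explains why the readings fall as they do.

From the compounds shown here alone, whether a free carboxylic acid or a dimethylamino group on this carbonyl carbon would read with compound 4 or with compound 1 remains open. Also open, going by these compounds, is whether a plain pyrrolidine amide, without the carboxylic acid, would keep the lower reading of compound 1.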